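Trimming the Aryl Substituent of Compound 2

The source may hold more compounds than are shown below. What is called first, only, known or untested is meant among the compounds shown, and "the series" means these compounds.

Compound 1 `CC(=O)n1cc(/C=C(/C(=O)O)c2ccc(OCc3ccccc3)cc2)c2cc(OCc3ccccc3)ccc21` was tested in a functional assay on KB cells (Homo sapiens) for cytotoxicity, read by MTT assay, with a stated time of 72 h (on this read-out lower numbers stand for stronger inhibition and higher numbers for weaker inhibition), where compound 1 gave 43000 nM. Compound 2 `COc1ccc(OC)c(/C(=C\c2cn(C(C)=O)c3ccc(OCc4ccccc4)cc23)C(=O)O)c1` stands differently: in this assay compound 2 gave > 100000 nM, which is a limit of the assay rather than a number. Nothing more is known of compound 2 than the limit of > 100000 nM in this assay, at which 1 of the 2 values shown sits. Compound 3 `COc1ccc(/C(=C\c2cn(C(C)=O)c3ccc(OCc4ccccc4)cc23)C(=O)O)cc1` differs from compound 2 in one place: 4-methoxyphenyl in place of 2,5-dimethoxyphenyl on a double-bonded chain carbon bound to a carbonyl carbon and a double-bonded chain carbon. Going by the values given here, no measured step between two compounds of this set is available, so the size of the change can only be judged loosely; the expectation is a modest step in this assay from compound 2 to compound 3 toward stronger inhibition, an at least 1.4-fold lower number from compound 2 to compound 3 (0.15 log units; that floor lies within the scatter), with a real chance that it stays within the scatter or that only a limit is read again. On that basis compound 3 is expected to give 70000 nM in this assay, with a range from 25000 nM to 200000 nM.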

Compound 3, half-maximal inhibitory concentration: > 100000 nM
Compound 3 gave a limit, no number; the forecaster's own chance of this, stated with the estimate: 40%; at least 1.4-fold (0.15 log units) between middle value and limit.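

The result ties the position to the phenyl on the saturated chain carbon bound to an oxygen on an aromatic ring. Going by these compounds alone, with hydrogen in place of that phenyl, this assay shows an at least 2.3-fold higher number from compound 1 to compound 3 (0.36 log units; beyond the scatter), so a step beyond the scatter now separates the only compound with a number from a compound without one. Compound 3 gives > 100000 nM, which is a limit of the assay, and the step from the 2,5-dimethoxyphenyl of compound 2 to the 4-methoxyphenyl cannot be read, because both compounds end at the same limit: the limit of > 100000 nM in this assay, at which 2 of the 3 values shown sit.

From the compounds shown here alone, how far compound 3 lies beyond compound 1 remains unknown, as does any difference between compound 2 and compound 3. Going by these compounds, whether a longer chain or an amine in place of that phenyl would restore a number in this assay also stays open.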